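Adding a Methyl Branch and Liver Microsome Clearance

A few compounds are considered here, and "the series" means these few. Any claim that something is new, unique, unknown or untested is made for them only; others in the source may bear on it.

Measured in an ADME assay on microsomes from liver (Homo sapiens) for metabolic stability; a higher number here means faster removal of the compound, a lower number slower removal:
Compound 1 `COc1ccc([C@H](C)NC(=O)Cn2nnc3ccccc3c2=O)cc1` gives 13 mL/min/kg.
Compound 2 `COc1ccc([C@H](C)NC(=O)C(C)n2nnc3ccccc3c2=O)cc1` reaches the assay limit < 9.9 mL/min/kg, which is a limit and not a number.
Compound 3 `CC[C@H](NC(=O)Cn1nnc2ccccc2c1=O)c1ccc(C)cc1` gives 31 mL/min/kg.

Compound 1 and compound 2 differ by methyl in place of hydrogen on a saturated chain carbon bound to an aromatic nitrogen and a carbonyl carbon. This change gave an at least 1.3-fold lower number from compound 1 to compound 2 (0.11 log units; that floor lies within the scatter); the step is only a floor because of the limit of < 9.9 mL/min/kg in this assay, at which 1 of the 3 values shown sits. Compound 3 has the highest number of the two numbers measured, and its value and that of compound 1 lie further apart than the usual scatter. The difference between the core of compound 1 and that of compound 3 is not broken down here.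

Compound 4 `Cc1ccc([C@@H](NC(=O)Cn2nnc3ccccc3c2=O)C(C)C)cc1` is not yet measured. It differs from compound 3 by methyl in place of hydrogen on a saturated chain carbon bound to two saturated chain carbons. This is the same kind of change as from compound 1 to compound 2, but the place differs: there the carbon is bound to an aromatic nitrogen and a carbonyl carbon, here to two saturated chain carbons. The step expected for compound 4 is a 1.4-fold lower number from compound 3 to compound 4 (0.15 log units; within the scatter), resting on an at least 1.3-fold lower number from compound 1 to compound 2 (0.11 log units; that floor lies within the scatter). Compound 4 is therefore estimated at 22 mL/min/kg, within 10 mL/min/kg and 45 mL/min/kg.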

Compound 4, clearance: 34 mL/min/kg
Estimate against measurement, compound 4: 1.5-fold (0.19 log units) below; the range from low to high includes it.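

In this assay, the methyl that turns ethyl into isopropyl gave a 1.1-fold higher number from compound 3 to compound 4 (0.04 log units; within the scatter). Set beside the earlier methyl step, this single result does not settle whether the change carries from one core to another, and the two methyl groups also sit at different places: the same change on two cores in this assay, an at least 1.3-fold lower number (0.11 log units; that floor lies within the scatter) from compound 1 to compound 2 and a 1.1-fold higher number (0.04 log units; within the scatter) from compound 3 to compound 4; the limit leaves it open whether they differ. Going by these compounds, neither printed step lies beyond the scatter, but the true size of the earlier step remains unknown, since compound 2 stands at a limit and not at a number: the limit of < 9.9 mL/min/kg in this assay, at which 1 of the 4 values shown sits.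

The compounds shown leave open how the methyl would behave at one and the same place on both cores, for instance on the saturated chain carbon bound to an aromatic nitrogen and a carbonyl carbon in the core of compound 3. They also leave open whether a longer chain or a cyclopropyl ring in place of the isopropyl would move the number in this assay by more than the scatter.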